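The source may hold more compounds than are shown below. What is called first, only, known or untested is meant among the compounds shown, and "the series" means these compounds.

Measured so far:
Compound 1 `C/C1=C\CC[C@@]2(C)O[C@@H]2[C@H]2OC(=O)[C@@H](CN3CCN(C)CC3)[C@@H]2C[C@H]1O`: 57000 nM
Compound 2 `C/C1=C\CC[C@@]2(C)O[C@@H]2[C@H]2OC(=O)[C@@H](CN3CCCC3)[C@@H]2C[C@@H]1O`: 23000 nM

Both values come from a functional assay on SK-MEL-28 cells (Homo sapiens) for inhibition, read by MTT assay, with a stated time of 72 h; on this read-out higher numbers stand for weaker inhibition and lower numbers for stronger inhibition. Of the two, compound 2 has the lower number and so the stronger inhibition, and its gap to compound 1 lies beyond the usual scatter. Compound 3 `C/C1=C\CC[C@@]2(C)O[C@@H]2[C@H]2OC(=O)[C@@H](CN3CCN(C)CC3)[C@@H]2C[C@@H]1O` has not been measured. It carries 4-methylpiperazin-1-yl in place of the pyrrolidin-1-yl of compound 2, on a saturated chain carbon bound to a saturated ring carbon: 4-methylpiperazin-1-yl in place of pyrrolidin-1-yl on a saturated chain carbon bound to a saturated ring carbon. Among the measured compounds shown here, no measured pair shows this change alone, so the expectation is rough. In this assay, a small shift toward weaker inhibition is expected, a 1.5-fold higher number from compound 2 to compound 3 (0.18 log units; within the scatter), and it is expected to stay within the scatter. Compound 3 is estimated at 35000 nM, with an expected range of 15000 nM to 80000 nM.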

Compound 3, half-maximal inhibitory concentration: 23000 nM
Compound 3: middle estimate off by 1.5-fold (0.18 log units), on the high side, within the range that was stated.
By their numbers in this assay, from the lowest: compounds 2 and 3 (each within the scatter of the next); then compound 1.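

In this assay, the swap of pyrrolidin-1-yl for 4-methylpiperazin-1-yl on a saturated chain carbon bound to a saturated ring carbon gives no change at the digits printed from compound 2 to compound 3 (within the scatter), so the two amine rings are not told apart here. The stereocentre does register, with S in place of R giving a 2.5-fold lower number from compound 1 to compound 3 (0.39 log units; beyond the scatter). That modest step can be pinned on this one centre: the fact that compounds 1 and 3 differ only in the configuration as drawn

On these data alone, whether an open-chain amine such as dimethylamino, or morpholin-4-yl, would match these rings on that carbon remains open. So does whether pyrrolidin-1-yl responds to the same change of configuration.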